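Swapping the dichlorophenyl arm for a bromo-fluoro one

The source may report more compounds than this note shows. Statements on the series, on what has been measured and on what is new or still open speak of the compounds shown alone.

Compound 1 `C=CCn1c(=O)/c(=C\c2ccc(Cl)c(Cl)c2)[nH]c(=O)/c1=C\c1ccccc1OC` is the starting point. In a functional assay on NCI-H1975 cells (Homo sapiens) for cytotoxicity, read by CCK-8 assay, with a stated time of 72 h (a higher number here means a weaker inhibitor, a lower number a stronger inhibitor), compound 1 is reported as "not active" (no number reported), so no single number marks where it stands, only the statement that it showed no useful effect. A related compound, compound 2 `COc1ccccc1/C=c1\c(=O)[nH]/c(=C/c2cccc(Cl)c2Cl)c(=O)n1C`, carries a methyl instead of an allyl on the shared core and a differently substituted dichlorophenyl arm; in this assay compound 2 gives 300 nM. Among the compounds with values here, these two values show that one member of this family does have measurable potency while compound 1 does not, but with no step between them only that contrast can be stated.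

Compound 3 `C=CCn1c(=O)/c(=C\c2ccc(F)c(Br)c2)[nH]c(=O)/c1=C\c1ccccc1OC` differs from compound 1 in one place: 3-bromo-4-fluorophenyl in place of 3,4-dichlorophenyl on a double-bonded chain carbon bound to an aromatic carbon. Within the data shown here, no measured step of this kind is available, so the size of the effect is unknown. Because compound 1 is "not active" (no number reported), there is no numerical baseline to shift from, and a modest or no real change in this assay is the plainest expectation. Compound 3 is therefore expected to remain weak, at an estimated 8000 nM, with a range of 1500 nM to 40000 nM.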

Compound 3, half-maximal inhibitory concentration: "not active" (no number reported)
Compound 3 has no reported number here, and the estimate cannot be compared.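

Compound 1 and compound 3 are both reported as "not active" (no number reported), with no number for either, so no step can be read between them. As far as these compounds go, whether 3-bromo-4-fluorophenyl in place of 3,4-dichlorophenyl changes potency at all remains open. No supporting measurement bears on this result.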